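Swapping the Furan Attachment Point on a Shared Core

A few compounds are considered here, and "the series" means these few. Any claim that something is new, unique, unknown or untested is made for them only; others in the source may bear on it.

Three compounds were measured in an assay on membranes from CHO cells for displacement of a labelled ligand from adenosine receptor A1 (Homo sapiens), read by scintillation counting, with a stated time of 60 min, tested at 1 uM; a higher number here means more inhibition at the concentration tested (going by the name of the read-out), a lower number less inhibition:
compound 1, `CCCOC(=O)C1=C(C)N(C)C(=O)NC1c1ccco1`: 3%
compound 2, `CCCOC(=O)C1=C(C)N(C)C(=O)NC1c1ccoc1`: 1%
compound 3, `CCC(CC)OC(=O)C1=C(C)NC(=O)NC1c1ccco1`: 2%

Compound 1 and compound 2 differ in one place, (furan-3-yl in place of furan-2-yl on a saturated ring carbon). The step of a number 2 percentage points lower from compound 1 to compound 2 (within the scatter) is reported as lying within the usual scatter, so the two numbers cannot be told apart. Compound 3 carries a core that differs from the core of compound 1 in more than one place, and the difference between the two cores is not broken down here. Its number in this assay sits within the scatter of both compound 1 and compound 2, so nothing can be said about an order among the three.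

Compound 4, `CCC(CC)OC(=O)C1=C(C)NC(=O)NC1c1ccoc1`, is not yet measured. It differs from compound 3 by furan-3-yl in place of furan-2-yl on a saturated ring carbon. For the measured compounds named here, this is the same kind of change as the one from compound 1 to compound 2, but the surroundings are not identical: in compound 3 the saturated ring carbon is next to the ring atom that bears a group of 8 heavy atoms, whereas in compound 1 it is next to the ring atom that bears a propoxycarbonyl group.

Because the earlier change gave a number 2 percentage points lower from compound 1 to compound 2 (within the scatter), the step of no change at the digits printed from compound 3 to compound 4 (within the scatter) for compound 4 is expected to be small as well. Compound 4 is therefore estimated at 2%, with a range from -5% to 9% expected.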

Compound 4, a percentage reported as inhibition, at one concentration (the size of the read-out at that concentration, not a potency): 17%
Compound 4: the middle estimate sits 15 percentage points below what was measured; measured number above the stated range.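

In this assay, furan-3-yl in place of furan-2-yl on a saturated ring carbon gave a number 15 percentage points higher from compound 3 to compound 4 (beyond the scatter), so on this core the attachment point of the furan does register in the read-out. Set beside the earlier step, the same change did not carry over unchanged from one core to the other: the same change on two cores in this assay, a number 2 percentage points lower (within the scatter) from compound 1 to compound 2 and a number 15 percentage points higher (beyond the scatter) from compound 3 to compound 4, 17 percentage points apart, beyond the scatter of two such steps This shows that the step seen on the core of compound 1 could not be transferred to the core of compound 3, but it does not show which of the several differences between the two cores matters, and it rests on a single pair of compounds for each core, with compound 4 at 17% read at one concentration and not as a potency.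

The compounds shown leave open whether the larger step follows the group of 8 heavy atoms or another of the places in which the two cores differ, as no compound here separates those differences. They also leave open how the furan swap would behave with a carboxylic acid or an amide in place of the ester, or how a thiophene would compare with either furan on these cores.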